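The source may report more compounds than this note shows. Statements on the series, on what has been measured and on what is new or still open speak of the compounds shown alone.

Compound 1 `CCc1cccc(Nc2cc(NC(=O)Nc3cc(OC)cc(OC)c3)ncn2)c1`: 23%
Compound 2 `COc1cc(NC(=O)Nc2cc(Nc3ccc(C)c(F)c3)ncn2)cc(OC)c1`: 30.6%

In a functional assay on NCI-H520 cells (Homo sapiens) for inhibition, read by MTT assay, with a stated time of 48 h, tested at 10 uM (a higher number here means more inhibition at the concentration tested (going by the name of the read-out), a lower number less inhibition), compound 2 gives 30.6%, while compound 1 gives 23%. The step of a number 7.6 percentage points higher from compound 1 to compound 2 (within the scatter) lies within the scatter, so the two compounds are not separated by these numbers. Compound 3 `COc1cc(NC(=O)Nc2cc(Nc3cc(C)cc(F)c3)ncn2)cc(OC)c1` differs from compound 2 by 3-fluoro-5-methylphenyl in place of 3-fluoro-4-methylphenyl on a nitrogen on an aromatic ring. Among the compounds with values here, the only measured step at this nitrogen is the one just mentioned, and it stayed within the scatter, so no step beyond the scatter is expected here either. Compound 3 is estimated at 28%, with a range from 12% to 45%. This expected step is a number 2.6 percentage points lower from compound 2 to compound 3 (within the scatter).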

Compound 3, a percentage reported as inhibition, at one concentration (the size of the read-out at that concentration, not a potency): 24.5%
Beside the measured number, compound 3's estimate is 3.5 percentage points above it; low and high end bracket the measured number.
By their numbers in this assay, from the lowest: compounds 1, 3 and 2 (each within the scatter of the next).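

In this assay, 3-fluoro-5-methylphenyl in place of 3-fluoro-4-methylphenyl on the nitrogen gives a number 6.1 percentage points lower from compound 2 to compound 3 (within the scatter) and so the same atoms, joined differently, are not told apart here. Set against 3-ethylphenyl, the same group gives a number 1.5 percentage points higher from compound 1 to compound 3 (within the scatter) and so all three groups at this nitrogen now lie within the scatter of one another. No supporting measurement bears on this result.

Going by these compounds, whether a group of another kind at this nitrogen, such as one carrying an amine or a carboxylic acid, would give a step beyond the scatter stays open.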